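The source may report more compounds than this note shows. Statements on the series, on what has been measured and on what is new or still open speak of the compounds shown alone.

Compound 3 `CN1CCN(CCCN(c2nc3cc(F)c(F)cc3[nH]2)[C@@H]2CC[C@]3(c4cccc(CO)c4)C[C@@H]3C2)CC1` gives the highest number of the three measured in an assay on isolated protein for binding affinity to melanin-concentrating hormone receptor 1 (Homo sapiens) (on this read-out higher numbers stand for weaker inhibition and lower numbers for stronger inhibition), where compound 3 gives 70.8 nM. Compound 1 `CN1CCN(CCCN(c2nc3cc(F)c(F)cc3[nH]2)[C@@H]2CC[C@]3(c4cccc(C#N)c4)C[C@@H]3C2)CC1` gives 8.4 nM, and compound 2 `CS(=O)(=O)N1CCC(CN(c2nc3cc(F)c(F)cc3[nH]2)[C@@H]2CC[C@]3(c4cccc(C#N)c4)C[C@@H]3C2)CC1` gives 27 nM. The two measured steps are a 3.2-fold higher number from compound 1 to compound 2 (0.51 log units; beyond the scatter) and an 8.4-fold higher number from compound 1 to compound 3 (0.93 log units; beyond the scatter). Compound 4 `CN1CCN(CCCN(c2nc3cc(F)c(F)cc3[nH]2)[C@@H]2CC[C@]3(c4cccc(CN5CC[C@H](O)C5)c4)C[C@@H]3C2)CC1` differs from compound 3 by 3-hydroxypyrrolidin-1-yl in place of hydroxy on a saturated chain carbon bound to an aromatic carbon. For the measured compounds named here, no measured step shows this change or any change at this position other than the cyano-to-hydroxymethyl step from compound 1 to compound 3, which altered the group on the aromatic carbon rather than extending the saturated chain carbon. That step gives only a loose guide to the sensitivity of this part of the shared core, so a step of at most modest size in this assay is expected, in either direction. The estimate for compound 4 is therefore a number close to that of compound 3, with the step of a 1.6-fold lower number from compound 3 to compound 4 (0.20 log units; within the scatter) expected to stay near the scatter. Compound 4 is estimated at 45 nM, with a range from 12 nM to 170 nM.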

Compound 4, inhibition constant: 441 nM
For compound 4 the middle estimate is 9.8-fold (0.99 log units) below the measured one; the whole stated range lies below it.
By their numbers in this assay, from the lowest: compound 1; then compound 2; then compound 3; then compound 4.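

In this assay, the step from hydroxymethyl to (3-hydroxypyrrolidin-1-yl)methyl is a 6.2-fold higher number from compound 3 to compound 4 (0.79 log units; beyond the scatter), and this adds to the loss already seen on leaving the nitrile. Measured against the nitrile directly, the whole replacement on the aromatic carbon is a 53-fold higher number from compound 1 to compound 4 (1.72 log units; beyond the scatter). The position therefore does not simply accept a larger group on the saturated chain carbon bound to an aromatic carbon: here, the added five-membered ring goes with further weakening rather than a return toward compound 1.

As far as these compounds go, whether this loss follows the ring, its hydroxy or its nitrogen stays open, and a pyrrolidin-1-ylmethyl group without the hydroxy, or a plain aminomethyl group, would help to separate these. Nothing available offers an explanation for the size of this step.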